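A Fluoro Added to the Outer Phenyl of Compound 2

A few compounds are considered here, and "the series" means these few. Any claim that something is new, unique, unknown or untested is made for them only; others in the source may bear on it.

Of the compounds shown here, two have numbers so far, compound 1 `C#Cc1cccc(N/N=N/c2ccc(C(=N)N)cc2)c1` and compound 2 `N=C(N)c1ccc(/N=N/Nc2cccc(C#Cc3ccccc3)c2)cc1`. In a functional assay on MDA-MB-231 cells (Homo sapiens) for antiproliferative activity, read by WST assay, with a stated time of 72 h (a lower number here means a stronger inhibitor of growth, a higher number a weaker inhibitor of growth), compound 1 gives 20500 nM and compound 2 gives 9500 nM, the lower of the two numbers. Within the data shown here, the only measured step is a 2.2-fold lower number from compound 1 to compound 2 (0.33 log units; beyond the scatter), which comes from phenyl in place of hydrogen on a triple-bonded carbon.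

The next compound, compound 3 `N=C(N)c1ccc(/N=N/Nc2cccc(C#Cc3ccc(F)cc3)c2)cc1`, differs from compound 2 in one place: fluoro in place of hydrogen on an aromatic carbon. This is fluoro in place of hydrogen on an aromatic carbon, which turns phenyl into 4-fluorophenyl. Among the measured compounds shown here, no measured pair tests a fluoro change, so the single step gives only a loose guide. Adding a whole phenyl to compound 1 produced the modest step of a 2.2-fold lower number from compound 1 to compound 2 (0.33 log units; beyond the scatter), and a lone fluoro is a far smaller addition. In this assay, then, no change beyond the usual scatter is expected, and the estimated step is a 1.1-fold lower number from compound 2 to compound 3 (0.05 log units; within the scatter). For compound 3, the expected value is 8500 nM, with an estimated range from 4500 nM to 16000 nM.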

Compound 3, concentration for 50% growth inhibition: 5500 nM
Beside the measured number, compound 3's estimate is 1.5-fold (0.19 log units) above it; the range from low to high includes it.
By their numbers in this assay, from the lowest: compounds 3 and 2 (each within the scatter of the next); then compound 1.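

The outer phenyl ring of compound 2 can carry a fluoro, on an aromatic carbon para to a large group, with no clear change in this assay (a 1.7-fold lower number from compound 2 to compound 3 (0.24 log units; within the scatter)), so compound 2 and compound 3 cannot be told apart here. The earlier pair showed only the effect of adding a phenyl on the triple-bonded carbon; this result adds that the ring itself can take a substituent at this place while the number stays well clear of that of compound 1, since 4-fluorophenyl in place of hydrogen on that carbon gives a step beyond the scatter (a 3.7-fold lower number from compound 1 to compound 3 (0.57 log units; beyond the scatter)). Nothing measured here accounts for these numbers, and no outside evidence bears on the result.

On these data alone, a single fluoro says little about larger groups or groups of a different kind, so it remains open whether a chloro, a methoxy, an amine or a carboxylic acid at this same place would also leave the number within the scatter of compound 2. Among these compounds, it also remains open whether a fluoro on another carbon of this ring would behave like the one in compound 3.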